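The compounds below may be only part of what the source reports. "The series", "measured", "known", "first", "only" and "open" are said of these compounds alone.

In a functional assay on MCF7 cells (Homo sapiens) for antiproliferative activity, read by MTT assay, with a stated time of 48 h (on this read-out higher numbers stand for weaker inhibition and lower numbers for stronger inhibition), the measured compounds give these values:
compound 1 `COc1ccc(OC)c(CN2CCc3nc(N4CCN(c5ncccn5)CC4)ncc3C2)c1` gives 53300 nM
compound 2 `COc1ccc(OC)c(C(=O)N2CCc3nc(N4CCN(c5ncccn5)CC4)ncc3C2)c1` gives 43300 nM
compound 3 `O=C(c1ccc(F)cc1)N1CCc2nc(N3CCN(c4ncccn4)CC3)ncc2C1` gives 46200 nM

On these numbers compound 3 cannot be told apart from the other two. Compound 4 `O=C(c1ccc(O)cc1O)N1CCc2nc(N3CCN(c4ncccn4)CC3)ncc2C1` carries 2,4-dihydroxyphenyl in place of 4-fluorophenyl on a carbonyl carbon, a change counted as 2,4-dihydroxyphenyl in place of 4-fluorophenyl on a carbonyl carbon in full. For the measured compounds named here, two measured steps bear on it. Swapping the group on that carbonyl carbon gave a 1.1-fold higher number from compound 2 to compound 3 (0.03 log units; within the scatter) and replacing the whole (4-fluorophenyl)carbonyl gave a 1.2-fold lower number from compound 1 to compound 3 (0.06 log units; within the scatter) as its result. Going by the values given here, no measured compound carries 2,4-dihydroxyphenyl, so the expectation remains loose. The estimated step is a 1.5-fold lower number from compound 3 to compound 4 (0.19 log units; within the scatter) and no shift beyond the scatter is expected in this assay here. For compound 4 the estimate is 30000 nM with an expected range from 8000 nM to 70000 nM as the likely span.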

Compound 4, half-maximal inhibitory concentration: 17500 nM
The estimate for compound 4 lay 1.7-fold (0.23 log units) above the measured number; low and high end bracket the measured number.
By their numbers in this assay, from the lowest: compound 4; then compounds 2, 3 and 1 (each within the scatter of the next).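

In this assay the group on this carbonyl carbon turns out able to shift the number: 2,4-dihydroxyphenyl in place of 4-fluorophenyl gave a 2.6-fold lower number from compound 3 to compound 4 (0.42 log units; beyond the scatter) while the earlier swaps all stayed within the scatter. Set against 2,5-dimethoxyphenyl the same group gave a 2.5-fold lower number from compound 2 to compound 4 (0.39 log units; beyond the scatter) and the whole (2,4-dihydroxyphenyl)carbonyl against 2,5-dimethoxybenzyl gave a 3.0-fold lower number from compound 1 to compound 4 (0.48 log units; beyond the scatter) so all three steps are modest yet beyond the scatter. Nothing shown here gives a reason for this shift. Still open, from the compounds shown here alone, is whether a single hydroxy group would be enough, and whether an aminophenyl or a carboxyphenyl on this carbonyl carbon would move the number as far.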